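Adding a Methoxy Group to Compound 3

The source may hold more compounds than are shown below. What is called first, only, known or untested is meant among the compounds shown, and "the series" means these compounds.

Measured so far in a functional assay on MCF7 cells (Homo sapiens) for antiproliferative activity, read by MTT assay, with a stated time of 48 h; a higher number here means a weaker inhibitor, a lower number a stronger inhibitor:
- Compound 1 `Clc1ccc2[nH]c(-c3cn(-c4ccccc4)nc3-c3ccccc3)nc2c1` gives 1960 nM
- Compound 2 `Cc1cc2nc(-c3cn(-c4ccccc4)nc3-c3ccccc3)[nH]c2cc1C` gives > 50000 nM, which is a limit of the assay and not a number
- Compound 3 `Clc1cc2nc(-c3cn(-c4ccccc4)nc3-c3ccccc3)[nH]c2cc1Cl` gives 7560 nM

Of the two values that are true numbers, compound 3 holds the higher one. Compound 4 `COc1ccc(-c2nn(-c3ccccc3)cc2-c2nc3cc(Cl)c(Cl)cc3[nH]2)cc1` differs from it by one change: methoxy in place of hydrogen on an aromatic carbon. This turns phenyl to 4-methoxyphenyl. Going by the values given here, the only measured step that can guide an expectation is a 3.9-fold higher number from compound 1 to compound 3 (0.59 log units; beyond the scatter). That step involves chloro rather than methoxy and sits at another place, so it suggests a modest size at most and gives no direction. The expected shift is therefore small, an estimated 1.3-fold lower number from compound 3 to compound 4 (0.10 log units; within the scatter). For compound 4 the estimated value is 6000 nM, with an expected range from 1500 nM to 30000 nM.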

Compound 4, half-maximal inhibitory concentration: 13200 nM
The estimate for compound 4 lay 2.2-fold (0.34 log units) below the measured number; the measured number falls inside the stated range.
By their numbers in this assay, from the lowest: compound 1; then compounds 3 and 4 (each within the scatter of the next). At a limit, above all of these: compound 2.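

Going by these compounds alone, all the earlier compounds carry a plain phenyl at this place, so compound 4 gives the first reading of a group on that ring. In this assay, phenyl to 4-methoxyphenyl gives a 1.7-fold higher number from compound 3 to compound 4 (0.24 log units; within the scatter), so methoxy at this carbon leaves compound 4 indistinguishable from compound 3. Nothing available here accounts for this result.

From the compounds shown here alone, it remains open whether a larger group, such as an amine or a carboxylic acid, at this carbon would shift the number beyond the scatter. Methoxy on the otherwise identical scaffold of compound 1, which gives 1960 nM, is equally open.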